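The source may report more compounds than this note shows. Statements on the series, on what has been measured and on what is new or still open speak of the compounds shown alone.

In a functional assay on HeLa cells (Homo sapiens) for cytotoxicity, read by WST assay, with a stated time of 48 h (a higher number here means a weaker inhibitor, a lower number a stronger inhibitor), compound 1 `COc1cc(C(c2ccc(O)c(OC)c2)[C@H](CF)C(C)C)ccc1O` gives 19000 nM and compound 2 `CC[C@H](C(C)C)C(c1ccc(O)c(OC)c1)c1ccc(O)c(OC)c1` gives 9700 nM, so these two values lie within the usual scatter of each other. Compound 3 `COc1cc(C(c2ccc(O)c(OC)c2)[C@H](CC(C)C)C(C)C)ccc1O` is built from compound 2 by one change: isopropyl in place of methyl on a saturated chain carbon, three bonds along the chain from two aromatic carbons. Cut one bond further out, this reads as ethyl to isobutyl. Among the compounds with values here, only one measured step bears on it, the swap of fluoro for methyl at that same place: a 2.0-fold lower number from compound 1 to compound 2 (0.29 log units; within the scatter), which is within the scatter. Within the data shown here, no compound carrying a group of this size at that place has been measured, so the evidence is thin and no clear direction can be expected. The expected change is small, a 1.2-fold lower number from compound 2 to compound 3 (0.08 log units; within the scatter), and no step beyond the scatter is expected. For compound 3, the estimated value is 8000 nM, with an expected range of 3000 nM to 20000 nM.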

Compound 3, half-maximal inhibitory concentration: 8200 nM
Estimate against measurement, compound 3: 1.0-fold (0.01 log units) below; measured number inside the range.
By their numbers in this assay, from the lowest: compounds 3, 2 and 1 (each within the scatter of the next, the first and the last beyond it).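

In this assay, isopropyl in place of methyl on a saturated chain carbon, three bonds along the chain from two aromatic carbons, gives a 1.2-fold lower number from compound 2 to compound 3 (0.07 log units; within the scatter) and so leaves these two compounds indistinguishable, even with the larger group. Isopropyl in place of fluoro at that same place gives a 2.3-fold lower number from compound 1 to compound 3 (0.36 log units; beyond the scatter) and is the first step here to clear the scatter, though only modestly. Nothing measured here explains either step.

The compounds shown carry only fluoro, methyl and isopropyl at this place, so it remains open how an amine, a carboxylic acid, a longer chain or a phenyl ring there would compare. All three also share the same core, which leaves open what a change to its hydroxy or methoxy groups would do.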